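Adding a Phenyl Ring to a Sulfonyloxy Succinimide

The source may hold more compounds than are shown below. What is called first, only, known or untested is meant among the compounds shown, and "the series" means these compounds.

Compound 1, `O=C1CCC(=O)N1S(=O)(=O)c1ccc(-c2ccccc2)cc1`: 700 nM
Compound 2, `O=C1CCC(=O)N1OS(=O)(=O)c1ccccc1`: 20000 nM
Compound 3, `O=C(OCN1C(=O)c2ccccc2S1(=O)=O)c1ccccc1Cl`: 8800 nM

Of the compounds shown here, three have been measured in an assay on membranes from HEK293T cells for inhibition of presenilin-associated rhomboid-like protein, mitochondrial (Homo sapiens), with a stated time of 30 min; on this read-out lower numbers stand for stronger inhibition and higher numbers for weaker inhibition. Compound 2 stands at the highest number of the three. Compound 3 gives a lower number, and that gap lies beyond the scatter; compound 1 gives a much lower number still, a gap far beyond the scatter. Compound 4, `O=C1CCC(=O)N1OS(=O)(=O)c1ccc(-c2ccccc2)cc1`, has not yet been measured. It differs from compound 2 in one place only: phenyl in place of hydrogen on an aromatic carbon. Among the compounds with values here, no pair of measured compounds differs by exactly this change, so no measured step gives its size directly. Compound 1 carries the same phenyl and shows the lowest number in this assay, but it also differs from compound 2 in the link between the sulfonyl group and the ring, so its value can only serve as a hint. On that hint, a step toward lower numbers, beyond the scatter, is expected for compound 4, namely a 5.0-fold lower number from compound 2 to compound 4 (0.70 log units; beyond the scatter). For compound 4 the estimate in this assay is 4000 nM, with a range from 1000 nM to 15000 nM.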

Compound 4, half-maximal inhibitory concentration: 1900 nM
Compound 4: middle estimate off by 2.1-fold (0.32 log units), on the high side; the measured number falls inside the stated range.
By their numbers in this assay, from the lowest: compound 1; then compound 4; then compound 3; then compound 2.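

In this assay, phenyl in place of hydrogen on an aromatic carbon, para to a large group, gives an 11-fold lower number from compound 2 to compound 4 (1.02 log units; beyond the scatter). This is a large step, and it shows that this position on the shared core accepts a whole added ring and that the added ring alone moves the number toward stronger inhibition. Compound 1 could only hint at this, as it also differs from compound 2 in the link between the sulfonyl group and the ring, and nothing available here accounts for the size of the step.

As far as these compounds go, only hydrogen and phenyl can be compared at this place, so the effect of a methoxy group, an amine or a carboxylic acid there remains open. From the compounds shown here alone, whether phenyl brings a step of similar size with the direct sulfonyl link of compound 1 also remains open.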